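This account rests on a few compounds, and the source may have more. Where it says the series, first, only, none or still open, it means among the compounds named here.

In a functional assay on PC-3 cells (Homo sapiens) for antiproliferative activity, read by WST assay, with a stated time of 3 days (on this read-out lower numbers stand for stronger inhibition and higher numbers for weaker inhibition), compound 1 `CCCOc1c(-c2cc(OC)c(OC)c(OC)c2)oc2ccccc2c1=O` gives 11800 nM, and compound 2 `CCN(CC)CCCCCOc1c(-c2cc(OC)c(OC)c(OC)c2)oc2ccccc2c1=O` gives 6600 nM. These two values stand level with each other, so compound 2 holds no clear place apart from compound 1. Compound 3 `CCCN(CCC)CCCCOc1c(-c2cc(OC)c(OC)c(OC)c2)oc2ccccc2c1=O` has not yet been measured. It differs from compound 2 by dipropylamino in place of (diethylamino)methyl on a saturated chain carbon, four bonds along the chain from an oxygen on an aromatic ring. Among the measured compounds shown here, no measured step tests this exchange directly. The only one that bears on it is the step that introduced the 2-(diethylamino)ethyl group, a 1.8-fold lower number from compound 1 to compound 2 (0.25 log units; within the scatter), and that step stays within the scatter. On that slim evidence, no step beyond the scatter is expected in this assay, in either direction. The estimated step is a 1.0-fold lower number from compound 2 to compound 3 (0.01 log units; within the scatter). For compound 3 the expected value is 6500 nM, with an estimated range from 2800 nM to 14000 nM.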

Compound 3, half-maximal inhibitory concentration: 11600 nM
Compound 3: the middle estimate sits 1.8-fold (0.25 log units) below what was measured; measured number inside the range.
By their numbers in this assay, from the lowest: compounds 2, 3 and 1 (each within the scatter of the next).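

In this assay, dipropylamino in place of (diethylamino)methyl on a saturated chain carbon, four bonds along the chain from an oxygen on an aromatic ring, gives a 1.8-fold higher number from compound 2 to compound 3 (0.24 log units; within the scatter) and so does not separate the two amine-bearing chains. Against the chain with no amine, (dipropylamino)methyl in place of hydrogen gives a 1.0-fold lower number from compound 1 to compound 3 (0.01 log units; within the scatter) and, like the 2-(diethylamino)ethyl group before it, leaves the number level with compound 1, so all three compounds stand within the scatter of one another. No measurement is available here that would explain these numbers. What the compounds shown leave open is whether a ring amine such as piperidine or morpholine at the chain end would give a step beyond the scatter. The same holds for a carboxylic acid in place of the amine and for a longer chain.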